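The source may report more compounds than this note shows. Statements on the series, on what has been measured and on what is new or still open speak of the compounds shown alone.

Compound 1 `COc1ccc(OCC2=NCCO2)cc1` and compound 2 `Clc1ccc(OCC2=NCCO2)cc1` share one core and differ only in a single group on an aromatic carbon. In a toxicity assay on the whole organism with Rattus norvegicus as the target, at a dose of 400 mg/kg by the oral route (on this read-out lower numbers stand for a weaker effect and higher numbers for a stronger effect at the one dose given), compound 1 gives 15%, and compound 2 gives 12%. For the measured compounds named here, the one measured step, a number 3 percentage points lower from compound 1 to compound 2 (within the scatter), with chloro in place of methoxy on an aromatic carbon, is within the scatter, so the two compounds stand within the scatter of each other in this assay and neither can be called the stronger. Compound 3 `Cc1cc(OCC2=NCCO2)ccc1Cl` is not yet measured; it differs from compound 2 by methyl in place of hydrogen on an aromatic carbon. Going by the values given here, no measured step concerns methyl in place of hydrogen, and the only step known, a number 3 percentage points lower from compound 1 to compound 2 (within the scatter), was within the scatter, so no step beyond the scatter is expected here either. The expected step of a number 2 percentage points higher from compound 2 to compound 3 (within the scatter) reflects this. Compound 3 is therefore estimated at 14% in this assay, with a range from 4% to 28%.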

Compound 3, a percentage reported as activity, at one dose (the size of the read-out at that dose, not a potency): 40%
Compound 3: the middle estimate sits 26 percentage points below what was measured; the measured number lies above the stated range.
By their numbers in this assay, from the lowest: compounds 2 and 1 (each within the scatter of the next); then compound 3.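

In this assay, for the compounds shown here, methyl in place of hydrogen on an aromatic carbon, ortho to a chloro group and meta to a group of 7 heavy atoms, gives a number 28 percentage points higher from compound 2 to compound 3 (beyond the scatter) and is the only step in this set beyond the scatter. It shows that this carbon of the ring is a place where a single added methyl can change the read-out, whereas chloro in place of methoxy on an aromatic carbon left the number within the scatter. Nothing at hand explains why the number rises with this change. As far as these compounds go, whether a longer chain such as ethyl, or an amine, on this same carbon would raise the number further remains open. So does whether methyl would give a step of the same size with methoxy in place of the chloro group.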